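From methyl to bromo on a shared core

The source may hold more compounds than are shown below. What is called first, only, known or untested is meant among the compounds shown, and "the series" means these compounds.

Compound 1 `O=c1c([C@@H]2C[C@H](c3ccccc3)ON2c2ccccc2)coc2ccc(Br)cc12`: > 60000 nM (a limit)
Compound 2 `CCO[C@H]1C[C@@H](c2coc3ccc(C)cc3c2=O)N(c2ccccc2)O1`: 31000 nM

Within the data shown here, in a functional assay on Caco-2 cells (Homo sapiens) for inhibition, read by sulforhodamine B assay, with a stated time of 48 h (a higher number here means a weaker inhibitor, a lower number a stronger inhibitor), compound 2 gives 31000 nM, the only true number available. The entry for compound 1 is a limit of the assay, not a number.

Compound 3 `CCO[C@H]1C[C@@H](c2coc3ccc(Br)cc3c2=O)N(c2ccccc2)O1` has bromo in place of methyl on an aromatic carbon of compound 2 (bromo in place of methyl on an aromatic carbon). Among the measured compounds shown here, no measured pair isolates this change, so no shift beyond the scatter is expected in this assay, in either direction. The expected change is a 1.0-fold lower number from compound 2 to compound 3 (0.01 log units; within the scatter). The estimate for compound 3 is 30000 nM, with an expected range from 13000 nM to 60000 nM.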

Compound 3, half-maximal inhibitory concentration: > 60000 nM
Compound 3 was reported as a limit (the forecaster's own chance of this, stated with the estimate: 25%); middle value at least 2.0-fold (0.30 log units) away from the limit.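

On the shared core, bromo in place of methyl on this aromatic carbon gives an at least 1.9-fold higher number from compound 2 to compound 3 (0.28 log units; that floor lies within the scatter) in this assay. Among these compounds, this is the first readable step at this position, though it gives only a floor, and the step between compound 1 and compound 3 cannot be read. The size stays unknown because the entry for compound 3 is a limit: the limit of > 60000 nM in this assay, at which 2 of the 3 values shown sit.

As far as these compounds go, whether an amine or a methoxy group on this aromatic carbon would give a lower number than compound 2 stays open. So does the true size of the bromo step.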